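The compounds below may be only part of what the source reports. "The series", "measured", "known", "first", "only" and "open" are said of these compounds alone.

Measured so far in an assay on cells for antagonist activity at transient receptor potential cation channel subfamily V member 1 (Homo sapiens), read by FLIPR and calcium flux, with a stated time of 6 min; a lower number here means a stronger inhibitor, a higher number a weaker inhibitor:
compound 1 `CCCN(CCC)c1nc(C(C)(C)C)ccc1CNC(=O)C(C)c1ccc(NS(C)(=O)=O)c(F)c1`, 2.5 nM
compound 2 `CCCCN(C)c1cc(C(C)(C)C)ccc1CNC(=O)C(C)c1ccc(NS(C)(=O)=O)c(F)c1`, 1 nM
compound 3 `CCCCOc1cc(C(C)(C)C)ccc1CNC(=O)C(C)c1ccc(NS(C)(=O)=O)c(F)c1`, 1.4 nM

Compound 3 gives the second highest of the three numbers in this assay. Its nearest neighbour is compound 2, and the step of a 1.4-fold higher number from compound 2 to compound 3 (0.15 log units; within the scatter) stays within the scatter. Going by the values given here, compound 1 shows a somewhat higher value than compound 3, but no single-change step connects the two, so only their two values can be compared.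

Compound 4 `CC(C)CCOc1cc(C(C)(C)C)ccc1CNC(=O)C(C)c1ccc(NS(C)(=O)=O)c(F)c1` carries the change (methyl in place of hydrogen on a saturated chain carbon bound to two saturated chain carbons). Among the compounds with values here, no measured step bears on this change: the only step in this assay, butoxy in place of butyl(methyl)amino, touches a different part of the molecule and was itself within the scatter. For compound 4 the expected step is therefore no change at the digits printed from compound 3 to compound 4 (within the scatter), none beyond the scatter. Compound 4 is estimated at 1.4 nM, with a range from 0.5 nM to 4 nM.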

Compound 4, inhibition constant: 0.6 nM
The estimate for compound 4 lay 2.3-fold (0.37 log units) above the measured number; the measured number falls inside the stated range.
By their numbers in this assay, from the lowest: compounds 4, 2, 3 and 1 (each within the scatter of the next, the first and the last beyond it).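

In this assay, going by these compounds alone, methyl in place of hydrogen on a saturated chain carbon bound to two saturated chain carbons, read as butyl to isopentyl, gives a 2.3-fold lower number from compound 3 to compound 4 (0.37 log units; beyond the scatter), the only step beyond the scatter, so this chain position responds to a single added carbon. Isopentyloxy in place of butyl(methyl)amino gives a 1.7-fold lower number from compound 2 to compound 4 (0.22 log units; within the scatter), which stays within the scatter. Nothing on hand accounts for the step.

As far as these compounds go, whether hexyloxy or a terminal amine on the chain would hold these values remains open. Also open, from the compounds shown here alone, is whether the same methyl on the butyl(methyl)amino chain would give a similar step.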